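Chloro-to-hydrogen step on the aryl ether amines

The source may report more compounds than this note shows. Statements on the series, on what has been measured and on what is new or still open speak of the compounds shown alone.

Compound 1 `Cc1cccc(C)c1OC[C@@H](N)c1ccccc1` gives 3020 nM in an assay on isolated protein for inhibition of sodium channel protein type 4 subunit alpha (Homo sapiens); on this read-out lower numbers stand for an effect already at smaller amounts and higher numbers for an effect only at larger amounts of compound. Compound 2 `Cc1cc(Cl)cc(C)c1OC[C@@H](N)c1ccccc1` gives 7940 nM in this assay, and compound 3 `Cc1cc(Cl)cc(C)c1OC[C@H](C)CN` gives 3720 nM. The measured step of a 2.6-fold lower number from compound 2 to compound 1 (0.42 log units; beyond the scatter) is hydrogen in place of chloro on an aromatic carbon. Compound 4 `Cc1cccc(C)c1OC[C@H](C)CN`, not yet measured, differs from compound 3 by hydrogen in place of chloro on an aromatic carbon. The difference between the cores of compound 3 and compound 2 is not broken down here. The two places are not identical: in one the changed carbon is para to a large group, in the other para to a group of 6 heavy atoms, so the change is of the same kind, not the same. Given the step from compound 2 to compound 1, a lower number is expected for compound 4, at about a 2.3-fold lower number from compound 3 to compound 4 (0.37 log units; beyond the scatter), with the estimate for compound 4 put at 1600 nM, between 700 nM and 3500 nM.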

Compound 4, half-maximal effective concentration: 23400 nM
The estimate for compound 4 lay 15-fold (1.17 log units) below the measured number, outside the stated range (above it).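

Chloro to hydrogen on the core of compound 3 gives a 6.3-fold higher number from compound 3 to compound 4 (0.80 log units; beyond the scatter) in this assay, the opposite direction to the step on the core of compound 1. The same change therefore has neither one direction nor one size across these two cores: the same change on two cores in this assay, a 2.6-fold lower number (0.42 log units; beyond the scatter) from compound 2 to compound 1 and a 6.3-fold higher number (0.80 log units; beyond the scatter) from compound 3 to compound 4, 17-fold (1.22 log units) apart, beyond the scatter of two such steps. This does not show which part of the cores sets the difference, and two pairs give no rule for any further core.

Still open, going by these compounds, is how fluoro, methoxy or trifluoromethyl on the same aromatic carbon would read on each core. Also open, on these data alone, is which feature of the amine side chain decides whether chloro raises or lowers the number.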